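The source may report more compounds than this note shows. Statements on the series, on what has been measured and on what is new or still open speak of the compounds shown alone.

Working notes on the series. In a functional assay on MCF7 cells (Homo sapiens) for cytotoxicity, read by sulforhodamine B assay, with a stated time of 48 h (on this read-out lower numbers stand for stronger inhibition of growth and higher numbers for weaker inhibition of growth), compound 1 (`Cc1nn(-c2ccccc2)c(Oc2ccc(-c3nc4cc([N+](=O)[O-])ccc4[nH]3)cc2)c1/C=N/NC(N)=O`) gives 13800 nM and compound 2 (`Cc1nn(-c2ccccc2)c(Sc2ccc(-c3nc4cc([N+](=O)[O-])ccc4[nH]3)cc2)c1/C=N/NC(N)=O`) gives 16600 nM while compound 3 (`Cc1nn(-c2ccccc2)c(Oc2ccc(-c3nc4cc(C(=O)O)ccc4[nH]3)cc2)c1/C=N/NC(N)=S`) gives 18100 nM on the same read-out. Compound 2 stands within the scatter of both compound 1 and compound 3. Among the measured compounds shown here, no measured pair differs in one place, so no direct step is available. Compound 4 (`Cc1nn(-c2ccccc2)c(Sc2ccc(-c3nc4cc(C(=O)O)ccc4[nH]3)cc2)c1/C=N/NC(N)=O`) is still unmeasured and follows from compound 2 by carboxy in place of nitro on an aromatic carbon with carboxy in place of nitro on an aromatic carbon. The carboxy compound 3 at 18100 nM lies within the scatter of the nitro compound 2 at 16600 nM and this gives no sign of a shift, so no step beyond the scatter is expected in this assay for this change. The expected step is small, a 1.0-fold higher number from compound 2 to compound 4 (0.01 log units; within the scatter) and within the scatter. For compound 4 the estimated value is 17000 nM with an expected range from 9000 nM to 32000 nM for now.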

Compound 4, concentration for 50% growth inhibition: 13600 nM
Compound 4: the middle estimate sits 1.3-fold (0.10 log units) above what was measured; the measured number falls inside the stated range.
By their numbers in this assay, from the lowest: compounds 4, 1, 2 and 3 (each within the scatter of the next).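

Carboxy in place of nitro on this aromatic carbon now has a direct reading in this assay where the earlier compounds offered none: the change gives a 1.2-fold lower number from compound 2 to compound 4 (0.09 log units; within the scatter) and does not separate the two groups at this position. The 5-nitro-1H-benzimidazol-2-yl and 5-carboxy-1H-benzimidazol-2-yl forms thus read alike on the core of compound 2. Nothing available bears on why the two read alike.

On these data alone, whether an amine or a methyl ester at this position would shift the number in this assay stays open. So does whether the same change reads alike on compound 1, which carries an oxygen link in place of sulfur.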